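Adding a second fluoro group to compound 2

A few compounds are considered here, and "the series" means these few. Any claim that something is new, unique, unknown or untested is made for them only; others in the source may bear on it.

Compound 1 `Nc1nc(N)c2cc(CSC(=S)N3CCN(C4CCCCC4)CC3)ccc2n1`: 4710 nM
Compound 2 `Nc1nc(N)c2cc(CSC(=S)N3CCN(c4ccccc4F)CC3)ccc2n1`: 6460 nM

In a functional assay on A549 cells (Homo sapiens) for antiproliferative activity, read by MTT assay, with a stated time of 72 h (on this read-out lower numbers stand for stronger inhibition and higher numbers for weaker inhibition), only these two compounds have been measured. Compound 2 stands at 6460 nM, within the scatter of compound 1, so the two cannot be told apart on these numbers.

The next compound, compound 3 `Nc1nc(N)c2cc(CSC(=S)N3CCN(c4ccc(F)cc4F)CC3)ccc2n1`, differs from compound 2 in one place: fluoro in place of hydrogen on an aromatic carbon. Fluoro takes the place of hydrogen on an aromatic carbon, turning 2-fluorophenyl into 2,4-difluorophenyl.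

Within the data shown here, only one measured step bears on this change, and only indirectly: a 1.4-fold higher number from compound 1 to compound 2 (0.14 log units; within the scatter). There, 2-fluorophenyl came in place of cyclohexyl on the same amine nitrogen, and the number stayed within the scatter. Among the measured compounds shown here, no measured pair shows a fluoro added to an aromatic ring. With that single step as the guide, the smaller edit from compound 2 is expected to give no step beyond the scatter in this assay, in either direction.

Compound 3 is estimated at 5500 nM, with an expected range of 2300 nM to 13000 nM. This estimate means an expected 1.2-fold lower number from compound 2 to compound 3 (0.07 log units; within the scatter).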

Compound 3, half-maximal inhibitory concentration: 5120 nM
The estimate for compound 3 lay 1.1-fold (0.03 log units) above the measured number; measured number inside the range.
By their numbers in this assay, from the lowest: compounds 1, 3 and 2 (each within the scatter of the next).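

In this assay, among these compounds, the first direct reading of a fluoro added to the aromatic ring gives a 1.3-fold lower number from compound 2 to compound 3 (0.10 log units; within the scatter) and so shows that fluoro in place of hydrogen on this carbon, para to a large group and meta to the existing fluoro group, leaves the number within the scatter. The wider exchange on the amine nitrogen in the ring gives a 1.1-fold higher number from compound 1 to compound 3 (0.04 log units; within the scatter) and thus also stays within the scatter, so neither 2-fluorophenyl nor 2,4-difluorophenyl can be told apart from cyclohexyl on these numbers. No supporting data accompany these results to say why the three compounds lie so close together.

The compounds shown leave open whether a methoxy group, a chloro group or a trifluoromethyl group on this same aromatic carbon, or an unsubstituted phenyl or a benzyl group on the amine nitrogen, would move the number beyond the scatter. They also leave open whether any change on this side of the molecule, rather than in the shared core, can separate one compound from another in this assay at all.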